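This account rests on a few compounds, and the source may have more. Where it says the series, first, only, none or still open, it means among the compounds named here.

Cytotoxicity is followed here in an ADME assay on HepG2 2.2.15 cells (Homo sapiens) for cytotoxicity (on this read-out lower numbers stand for higher toxicity in this test and higher numbers for lower toxicity in this test), run on a liver-derived human cell line. Of the compounds shown here, two have been tested. Compound 1, `O=C(Nc1ncc(Cc2ccc(Br)cc2)s1)c1cccs1`, gives in this assay only a limit of the assay, > 50000 nM. Compound 2, `CCN(CC)C(=O)Nc1ncc(C(Oc2ccc3cc(Br)ccc3c2)c2ccc(Cl)cc2)s1`, is reported in this assay as "not toxic" (no number reported), without any number attached. So compound 2 stands without a single value of its own, and the one other reading in the set sits at the limit of > 50000 nM in this assay, at which 1 of the 2 values shown sits, which marks the edge of what the test can report.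

Compound 3 is `Cc1ccc(C)c(S(=O)(=O)Nc2ncc(C(Oc3ccc4cc(Br)ccc4c3)c3ccc(Cl)cc3)s2)c1`. It differs from compound 2 in one place: (2,5-dimethylphenyl)sulfonyl in place of diethylcarbamoyl on a nitrogen on an aromatic ring. Going by the values given here, no measured pair in this set shows what such an exchange does to cytotoxicity, so there is no step to lean on. Both readings so far lie at or beyond the reach of the test, and nothing here points to a change beyond the usual scatter in either direction. Compound 3 is therefore expected to land around 50000 nM, most likely again as a limit rather than a number, within a range from 20000 nM to 100000 nM.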

Compound 3, half-maximal cytotoxic concentration: > 50000 nM
Compound 3 gave a limit, no number; the forecaster's own chance of this, stated with the estimate: 80%; the middle value sits exactly at the limit.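

In this assay compound 3 gives > 50000 nM, which is a limit of the assay and not a number. Compound 2 has no number either, so no step can be read between compound 2 and compound 3. On these data alone, what replacing diethylcarbamoyl with (2,5-dimethylphenyl)sulfonyl does to cytotoxicity, and at what concentration either compound would harm these cells, stays open.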